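Trimming the trimethoxy ring of a chalcone-pyrazole aniline

This account rests on a few compounds, and the source may have more. Where it says the series, first, only, none or still open, it means among the compounds named here.

Measured compounds:
- compound 1, `COc1ccc(-c2cc(/C=C/C(=O)c3ccc(N)cc3)[nH]n2)cc1`: 2800 nM
- compound 2, `COc1cc(-c2cc(/C=C/C(=O)c3ccc(N)cc3)[nH]n2)cc(OC)c1OC`: 1770 nM

In a functional assay on HOP-62 cells (Homo sapiens) for inhibition, read by sulforhodamine B assay, with a stated time of 48 h (a lower number here means a stronger inhibitor of growth, a higher number a weaker inhibitor of growth), compound 1 gives 2800 nM and compound 2 gives 1770 nM. Compound 2 thus has the lowest of the two numbers, but compound 1 sits close to it, within the scatter, so the two cannot be ranked against each other.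

Compound 3, `COc1ccc(-c2cc(/C=C/C(=O)c3ccc(N)cc3)[nH]n2)cc1OC`, has not yet been measured in this assay. It differs from compound 2 in one place: hydrogen in place of methoxy on an aromatic carbon. Among the compounds with values here, no step between two measured compounds mirrors this change. Since compound 1 and compound 2 differ only in the methoxy count on the same ring and still lie within the scatter of each other, no step beyond the scatter is expected here. The expected step is a 1.2-fold higher number from compound 2 to compound 3 (0.09 log units; within the scatter). Compound 3 is therefore estimated at 2200 nM, with a range from 900 nM to 5500 nM.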

Compound 3, concentration for 50% growth inhibition: 2800 nM
For compound 3 the middle estimate is 1.3-fold (0.10 log units) below the measured one; low and high end bracket the measured number.
By their numbers in this assay, from the lowest: compounds 2, 1 and 3 (each within the scatter of the next).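

Within the data shown here, compound 3 gives the first reading of a single methoxy change on this ring: hydrogen in place of methoxy, on the aromatic carbon ortho to a methoxy group, gives a 1.6-fold higher number from compound 2 to compound 3 (0.20 log units; within the scatter) in this assay. Read from the other side, methoxy in place of hydrogen on an aromatic carbon gives no change at the digits printed from compound 1 to compound 3 (within the scatter), so neither single change on this ring moves the number beyond the scatter, and all three compounds stand within the scatter of one another. Nothing available explains this result or bears on it.

The compounds shown carry only methoxy or hydrogen at these ring carbons, so they leave open whether a hydroxyl, a fluorine or a longer ethoxy chain there would give a step beyond the scatter. They also leave open whether the result holds if the amine on the other ring is replaced by a carboxylic acid.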